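Removing a Fluoro on a Pendant Ring in a Trifluoromethyl Series

The compounds below may be only part of what the source reports. "The series", "measured", "known", "first", "only" and "open" are said of these compounds alone.

Compound 1 `CCOC(=O)C1=Cc2ccccc2OC1(OCc1cn(-c2ccc(F)cc2)nn1)C(F)(F)F` carries a 4-fluorophenyl ring on its pendant group. In a functional assay on DU-145 cells (Homo sapiens) for inhibition, read by MTT assay, with a stated time of 24 h (on this read-out lower numbers stand for stronger inhibition and higher numbers for weaker inhibition), compound 1 gives 8900 nM. Compound 2 `CCOC(=O)C1=Cc2ccccc2OC1(OCc1cn(-c2ccccc2)nn1)C(F)(F)F` differs from it in one place: hydrogen in place of fluoro on an aromatic carbon. For compound 2 this assay reports only a limit, > 150000 nM, a value that sits at the limit of > 150000 nM in this assay, at which 2 of the 3 values shown sit. The step is an at least 16-fold higher number from compound 1 to compound 2 (1.22 log units; beyond the scatter).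

Compound 3 `O=C(O)C1=Cc2ccccc2OC1(OCc1cc(-c2ccc(F)cc2F)no1)C(F)(F)F` has a different core from compound 1; the difference between the two cores is not broken down here. For compound 3 this assay likewise reports only a limit, > 150000 nM. Compound 4 `O=C(O)C1=Cc2ccccc2OC1(OCc1cc(-c2ccc(F)cc2)no1)C(F)(F)F` has not yet been measured. It differs from compound 3 by hydrogen in place of fluoro on an aromatic carbon. This is the same kind of change as that from compound 1 to compound 2, but not the same: there the fluoro that leaves sits para to a large group, here it sits ortho to a large group and meta to a fluoro group.

Within the data shown here, compound 3 already sits at a limit, and the only measured example of this kind of change, an at least 16-fold higher number from compound 1 to compound 2 (1.22 log units; beyond the scatter), made the number higher. Compound 4 is therefore expected to remain at or beyond the same limit, with an expected step that the limit leaves unreadable from compound 3 to compound 4. The estimate for compound 4 in this assay is 200000 nM, within a range from 60000 nM to 600000 nM.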

Compound 4, half-maximal inhibitory concentration: 168000 nM
Beside the measured number, compound 4's estimate is 1.2-fold (0.08 log units) above it; low and high end bracket the measured number.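

No step can be read from compound 3 to compound 4 in this assay, since compound 3 carries only a limit and not a number: the limit of > 150000 nM in this assay, at which 2 of the 4 values shown sit.

The compounds shown leave open whether the change from 2,4-difluorophenyl to 4-fluorophenyl moves the number at all on the core of compound 3, and if it does, in which direction and how far.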